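The source may hold more compounds than are shown below. What is called first, only, known or untested is meant among the compounds shown, and "the series" means these compounds.

In a physicochemical assay for lipophilicity (on this read-out lower numbers stand for lower lipophilicity and higher numbers for higher lipophilicity), compound 3 `Cc1cccc(C2=NO[C@]3(C2)C(=O)O[C@@H]2[C@H]3CC[C@H](C)[C@]3(O)C=CC(=O)[C@@]23C)c1` gives 1.86, while compound 1 `C[C@H]1CC[C@@H]2[C@@H](OC(=O)[C@]23CC(c2ccc(Cl)cc2)=NO3)[C@]2(C)C(=O)C=C[C@@]12O` gives 2.09 and compound 2 `C[C@H]1CC[C@@H]2[C@@H](OC(=O)[C@]23CC(c2ccc([N+](=O)[O-])cc2)=NO3)[C@]2(C)C(=O)C=C[C@@]12O` gives 1.37. Compound 3 thus stands level with compound 1, with a number 0.23 log units lower from compound 1 to compound 3 (within the scatter), and clear of compound 2, with a number 0.49 log units higher from compound 2 to compound 3 (beyond the scatter). Compound 4 `Cc1ccc(C2=NO[C@]3(C2)C(=O)O[C@@H]2[C@H]3CC[C@H](C)[C@]3(O)C=CC(=O)[C@@]23C)cc1` brings 4-methylphenyl in place of 3-methylphenyl on a carbon with a double bond to nitrogen. Within the data shown here, no measured step makes this exact swap. The closest, a number 0.23 log units lower from compound 1 to compound 3 (within the scatter), exchanges a whole aryl group, and the larger a number 0.72 log units lower from compound 1 to compound 2 (beyond the scatter) replaces chloro with nitro, a far bigger change in kind. The expected result is a number 0.04 log units higher from compound 3 to compound 4 (within the scatter), so no real shift in this assay is anticipated. Compound 4 is estimated at 1.9, with an expected range of 1.6 to 2.2.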

Compound 4, partition coefficient: 1.86
For compound 4 the middle estimate is 0.04 log units above the measured one, within the range that was stated.
By their numbers in this assay, from the lowest: compound 2; then compounds 3, 4 and 1 (each within the scatter of the next).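

Moving the methyl from 3-methylphenyl to 4-methylphenyl keeps the same atoms and joins them differently, and in this assay this swap gives a flat result (no change at the digits printed from compound 3 to compound 4 (within the scatter)). Compound 4 also offers single swaps on an aromatic carbon: methyl in place of nitro gives a step beyond the scatter (a number 0.49 log units higher from compound 2 to compound 4 (beyond the scatter)), whereas methyl in place of chloro does not (a number 0.23 log units lower from compound 1 to compound 4 (within the scatter)). No outside evidence on these results is available. Still open, as far as these compounds go, is how this assay would respond to an amine or a carboxylic acid in place of the methyl on this aromatic ring.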